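Methylsulfanyl in Place of Amino on the Shared Core

A few compounds are considered here, and "the series" means these few. Any claim that something is new, unique, unknown or untested is made for them only; others in the source may bear on it.

Of the compounds shown here, three built on one shared core have so far been measured in a functional assay (spleen, spleen) for activation, with Mus musculus as the target; on this read-out lower numbers stand for an effect already at smaller amounts and higher numbers for an effect only at larger amounts of compound. Compound 1 `CCNc1nc(N)c2nc(O)n(Cc3ccccc3)c2n1` gives 1 uM, and compound 2 `CCc1nc(N)c2nc(O)n(Cc3ccccc3)c2n1` gives 1 uM; the step between them is no change at the digits printed from compound 1 to compound 2 (within the scatter). Compound 3 `Nc1nc(N)c2nc(O)n(Cc3ccccc3)c2n1` gives 10 uM, the highest of the three numbers, and the steps of a 10-fold higher number from compound 1 to compound 3 (1.00 log units; beyond the scatter) and a 10-fold higher number from compound 2 to compound 3 (1.00 log units; beyond the scatter) are both beyond the scatter. Compound 4 `CSc1nc(N)c2nc(O)n(Cc3ccccc3)c2n1` has not yet been measured. It differs from compound 3 in one place: methylsulfanyl in place of amino on an aromatic carbon. The measured step that bears most directly on this change is a 10-fold higher number from compound 2 to compound 3 (1.00 log units; beyond the scatter), in which an amino group on an aromatic carbon took the place of ethyl; read in the opposite direction, giving up the amino group at that aromatic carbon went with a modest but clear fall in the number. On this basis a fall of similar size is expected for compound 4 in this assay, a 5.0-fold lower number from compound 3 to compound 4 (0.70 log units; beyond the scatter). Compound 4 is therefore estimated at 2 uM, with a range from 0.5 uM to 10 uM.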

Compound 4, minimum effective concentration: 0.1 uM
Compound 4: the middle estimate sits 20-fold (1.30 log units) above what was measured; the whole stated range lies above it.
By their numbers in this assay, from the lowest: compound 4; then compounds 1 and 2 (each within the scatter of the next); then compound 3.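

In this assay, among the compounds shown here, the aromatic carbon between two ring nitrogen atoms responds far more strongly to its substituent than the earlier compounds showed, with methylsulfanyl in place of amino giving a 100-fold lower number from compound 3 to compound 4 (2.00 log units; beyond the scatter). Ethyl and ethylamino had given numbers within the scatter of each other, yet methylsulfanyl goes beyond both, with a 10-fold lower number from compound 2 to compound 4 (1.00 log units; beyond the scatter) and a 10-fold lower number from compound 1 to compound 4 (1.00 log units; beyond the scatter). Nothing at hand explains why this change has so large an effect.

Going by these compounds, it remains open whether the sulfur atom matters here or whether methoxy, with oxygen in its place, would give a number like that of compound 4. Also open, on these data alone, is how a longer chain on the sulfur, such as ethylsulfanyl or butylsulfanyl, would compare with methylsulfanyl at this position.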